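The source may report more compounds than this note shows. Statements on the series, on what has been measured and on what is new or still open speak of the compounds shown alone.

The account begins with compound 1, `CCCC(Oc1ccc(-n2cc(Cl)cn2)cc1)c1ccc(C(=O)NCCC(=O)O)cc1`, which in a functional assay on cells for antagonist activity at Glucagon receptor (Homo sapiens), read by cAMP accumulation, in the presence of a further agent that is not named here (a lower number here means a stronger inhibitor, a higher number a weaker inhibitor), gives 6500 nM. Among the three measured numbers this places compound 1 second from the top. Its nearest neighbour is compound 2, `O=C(O)CCNC(=O)c1ccc(C(Oc2ccc(-n3cc(C(F)(F)F)cn3)cc2)C2CC2)cc1`, which in this assay gives 15000 nM, a weaker inhibitor by a margin beyond the scatter. Furthest from it stands compound 3, `CCCC(Nc1cnc(-n2cc(C(F)(F)F)cn2)nc1)c1ccc(C(=O)NCCC(=O)O)cc1`, which in this assay gives 490 nM; compound 3 is the strongest of the three, its gap to each of the others lying beyond the scatter.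

The step of interest leads from compound 1 to compound 4, `CCCC(Oc1ccc(-n2cc(C(F)(F)F)c(C)n2)cc1)c1ccc(C(=O)NCCC(=O)O)cc1`, not yet measured in this assay. The two structures differ in one place: 3-methyl-4-(trifluoromethyl)-1H-pyrazol-1-yl in place of 4-chloro-1H-pyrazol-1-yl on an aromatic carbon. Within the data shown here, no measured pair in this set differs only by this exchange, so no computed step exists for it; compound 2 and compound 3 both carry a trifluoromethyl-bearing pyrazole but differ from compound 1 elsewhere too, so their values show only that such a group sits in both a weaker and a stronger inhibitor here. The step is therefore expected to be modest: a 1.3-fold lower number from compound 1 to compound 4 (0.11 log units; within the scatter), a slight shift toward a lower number or none beyond the scatter. Compound 4 is estimated to give 5000 nM in this assay, with a range from 1500 nM to 15000 nM.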

Compound 4, antagonist equilibrium constant: 8300 nM
Compound 4: middle estimate off by 1.7-fold (0.22 log units), on the low side; the range from low to high includes it.
By their numbers in this assay, from the lowest: compound 3; then compounds 1, 4 and 2 (each within the scatter of the next, the first and the last beyond it).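

In this assay, the exchange of 4-chloro-1H-pyrazol-1-yl for 3-methyl-4-(trifluoromethyl)-1H-pyrazol-1-yl gives a 1.3-fold higher number from compound 1 to compound 4 (0.11 log units; within the scatter), and this is the first pair shown that differs in this one place alone. At this position, on an aromatic carbon para to a large group, a pyrazole substituent of 10 heavy atoms therefore reads the same within the scatter as one of 6 heavy atoms, with the chlorine gone and a methyl and a trifluoromethyl in its stead. No measurement shown here accounts for this outcome.

The methyl and the trifluoromethyl enter together, so the compounds shown leave open how a pyrazole carrying only one of them would compare with the 4-chloro-1H-pyrazol-1-yl group of compound 1. Also open, on these data alone, are how a pyrazole bearing a nitrile or an amine would read at this position, and whether the same exchange would give a similar step on the other two compounds, compound 2 and compound 3, which differ from compound 1 elsewhere.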